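The source may report more compounds than this note shows. Statements on the series, on what has been measured and on what is new or still open speak of the compounds shown alone.

Compound 2 `CCc1ccc(NC2=CC(=O)c3nc4n(c3C2=O)[C@H]2OC[C@@H](O)[C@H]2OC4)cc1` and compound 1 `CCCc1ccc(NC2=CC(=O)c3nc4n(c3C2=O)[C@H]2OC[C@@H](O)[C@H]2OC4)cc1` share one core and differ in methyl in place of hydrogen on a saturated chain carbon, two bonds along the chain from an aromatic carbon. In a functional assay on ECa-109 cells for inhibition, with ECa-109 cell line (Homo sapiens) as the target, read by sulforhodamine B assay (on this read-out lower numbers stand for stronger inhibition and higher numbers for weaker inhibition), compound 2 gives 3080 nM. Compound 1 is recorded in this assay only as a limit, > 4000 nM. The step is an at least 1.2-fold higher number from compound 2 to compound 1 (0.11 log units; that floor lies within the scatter); its floor rests on (the limit of > 4000 nM in this assay, at which 1 of the 3 values shown sits), so the true size of the step is open. Compound 3 `COc1ccc(NC2=CC(=O)c3c(nc4n3[C@H]3OC[C@@H](O)[C@H]3OC4)C2=O)cc1` carries a different core; the difference between the two cores is not broken down here. In this assay compound 3 gives 3410 nM, which sits within the scatter of compound 2. Compound 4 `CCOc1ccc(NC2=CC(=O)c3c(nc4n3[C@H]3OC[C@@H](O)[C@H]3OC4)C2=O)cc1` is the unmeasured member; it differs from compound 3 in methyl in place of hydrogen on a saturated chain carbon bound to an oxygen on an aromatic ring. Around the place, the change in compound 1 sits two bonds along the chain from an aromatic carbon, whereas in compound 4 it sits on a saturated chain carbon bound to an oxygen on an aromatic ring, so it is the same kind of change, not the same change. From compound 3 to compound 4 a step of a 1.3-fold higher number from compound 3 to compound 4 (0.12 log units; within the scatter) is expected in this assay, resting on the earlier step of an at least 1.2-fold higher number from compound 2 to compound 1 (0.11 log units; that floor lies within the scatter) and on compound 3 already standing at 3410 nM. Compound 4 is accordingly estimated at 4500 nM, within 2000 nM to 10000 nM, with a real chance that this assay returns only a limit.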

Compound 4, half-maximal inhibitory concentration: > 4000 nM
Compound 4 ended at the assay's limit; the forecaster's own chance of this, stated with the estimate: 40%; the middle value is on the limit's open side.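

In this assay, going from methoxy to ethoxy gives an at least 1.1-fold higher number from compound 3 to compound 4 (0.06 log units; that floor lies within the scatter), and this figure is a floor set by a limit, not a measured size. Carried onto the core of compound 3, the change therefore gives a result that is compatible with the earlier step but does not establish a shared size, and the comparison of the two cores stays unresolved: the same change on two cores in this assay, an at least 1.2-fold higher number (0.11 log units; that floor lies within the scatter) from compound 2 to compound 1 and an at least 1.1-fold higher number (0.06 log units; that floor lies within the scatter) from compound 3 to compound 4; the limit leaves it open whether they differ Neither step shows that the change has any real effect on either core, and the true size of both steps stays unknown, with part of the series recorded only as a limit: the limit of > 4000 nM in this assay, at which 2 of the 4 values shown sit.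

The compounds shown leave open how a longer chain such as propoxy, or a group such as an amine or a carboxylic acid, would read in place of the ethoxy of compound 4 in this assay. Also open, on these data alone, is how the two cores compare when one group, for example ethyl, is held fixed on both.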